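The compounds below may be only part of what the source reports. "The series", "measured", "known", "first", "only" and "open" are said of these compounds alone.

Compound 1 `O=c1c(Cl)c(OCc2ccc(F)cc2F)cc(CO)n1-c1c(F)cccc1F`: < 10 ug/mL
Compound 2 `Cc1cc(OCc2ccc(F)cc2F)c(Br)c(=O)n1-c1cccc(C(N)=O)c1`: < 10 ug/mL
Compound 3 `Cc1cc(OCc2ccc(F)cc2F)c(Br)c(=O)n1-c1c(F)cccc1F`: < 10 ug/mL

All three compounds were tested in a physicochemical assay for solubility; on this read-out higher numbers stand for higher solubility and lower numbers for lower solubility. Compound 1 gives < 10 ug/mL, which is a limit and not a number. Compounds 2 and 3 give no number either, as every measured compound sits at the limit of < 10 ug/mL in this assay, at which 3 of the 3 values shown sit. Compound 1 therefore has no exact position among them, only a shared limit.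

The unmeasured compound 4 `O=c1c(Br)c(OCc2ccc(F)cc2F)cc(CO)n1-c1c(F)cccc1F` differs from compound 1 in one place: bromo in place of chloro on an aromatic carbon. This is bromo in place of chloro on an aromatic carbon, para to a hydroxymethyl group and meta to a 2,6-difluorophenyl group.

Going by the values given here, only one measured step is available: a step that the two limits leave unreadable from compound 2 to compound 3. That change lies at a different place, on the aromatic nitrogen, and both of its ends are limits, so it offers no size to carry over. Among the compounds with values here, no measured step swaps chloro for bromo. No step beyond the usual scatter is therefore expected in this assay, and no direction can be predicted.

The expected change is a step that the limit leaves unreadable from compound 1 to compound 4. For compound 4 the estimate is 6 ug/mL, with an expected range from 2 ug/mL to 12 ug/mL, and a result reported only as a limit is the likeliest outcome.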

Compound 4, solubility: < 10 ug/mL
Compound 4 was reported as a limit; the forecaster's own chance of this, stated with the estimate: 90%; the middle value lies beyond the limit too.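

Compound 4 also gives only a limit, so no new step can be read against compound 1 or compound 3, because all the values shown are limits: the limit of < 10 ug/mL in this assay, at which 4 of the 4 values shown sit.

The compounds shown leave open what exact value any of them has, and so whether bromo in place of chloro, or hydroxy in place of hydrogen, shifts the read-out of this assay at all.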